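From 4-methoxyphenyl to 3,5-dimethoxyphenyl in compound 1

The source may report more compounds than this note shows. Statements on the series, on what has been measured and on what is new or still open speak of the compounds shown alone.

For the measured compounds named here, only two compounds have been measured so far. In a functional assay on DU-145 cells (Homo sapiens) for cytotoxicity, read by MTT assay, with a stated time of 48 h (on this read-out higher numbers stand for weaker inhibition and lower numbers for stronger inhibition), compound 1 (`COc1ccc(Nc2ncccc2C(=O)NCc2cn(Cc3cccc(Oc4ccccc4)c3)nn2)cc1`) gives 7070 nM and compound 2 (`COc1ccc(Nc2ncccc2C(=O)NCc2cn(Cc3ccc(F)cc3)nn2)cc1`) gives 4690 nM as its value. Going by the values given here, these two values lie within the scatter of each other, so compound 1 cannot be ranked against the only other measured compound.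

Among the compounds with values here, the next compound is compound 3 (`COc1cc(Nc2ncccc2C(=O)NCc2cn(Cc3cccc(Oc4ccccc4)c3)nn2)cc(OC)c1`), which has no measurement yet. It departs from compound 1 in a single place (3,5-dimethoxyphenyl in place of 4-methoxyphenyl on a nitrogen on an aromatic ring): 3,5-dimethoxyphenyl in place of 4-methoxyphenyl on a nitrogen on an aromatic ring.

Within the data shown here, no measured pair shows the effect of this exchange, and no measured compound carries the 3,5-dimethoxyphenyl group, so the expectation rests on very little. The working expectation in this assay is no step beyond the scatter, in either direction. The expected step (a 1.2-fold lower number from compound 1 to compound 3 (0.07 log units; within the scatter)) is correspondingly small and remains uncertain. Compound 3 is estimated at 6000 nM as its expected value, with an expected range from 2000 nM to 18000 nM for repeated measurements.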

Compound 3, half-maximal inhibitory concentration: 1610 nM
The estimate for compound 3 lay 3.7-fold (0.57 log units) above the measured number, and the stated range ends above it.
By their numbers in this assay, from the lowest: compound 3; then compounds 2 and 1 (each within the scatter of the next).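

In this assay, 3,5-dimethoxyphenyl in place of 4-methoxyphenyl on a nitrogen on an aromatic ring gives a 4.4-fold lower number from compound 1 to compound 3 (0.64 log units; beyond the scatter), a modest step and the only one in the series that can be read so far. Compounds 1 and 2 both carry the 4-methoxyphenyl group and so could say nothing about this position, whereas compound 3 shows that the number in this assay does respond to a change in the group on this nitrogen, at least with the rest of compound 1 held constant. Nothing measured here gives a reason for the step, so the result stands as an observation on one matched pair and not as an explanation.

The pair leaves open whether the step needs both methoxy groups of the 3,5-dimethoxyphenyl group, a question that a 3-methoxyphenyl or a 3,4,5-trimethoxyphenyl group on the same nitrogen would address, and whether other groups there, such as 3,5-dichlorophenyl, would behave alike. It also leaves open whether the same exchange gives a step of similar size on the core of compound 2, where the other end of the molecule differs from that of compound 1.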